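The source may hold more compounds than are shown below. What is called first, only, known or untested is meant among the compounds shown, and "the series" means these compounds.

Working notes on the series, read in a functional assay on DU-145 cells (Homo sapiens) for inhibition, read by trypan blue exclusion, with a stated time of 72 h; a lower number here means a stronger inhibitor, a higher number a weaker inhibitor. Among the compounds with values here, compound 1 (`COC(=O)Cn1c(=O)c(S(=O)(=O)c2ccc(F)cc2F)cc2cnc(Nc3ccc4[nH]ccc4c3)nc21`) gives 10000 nM, the highest of the three numbers so far. Compound 2 (`Cn1c(=O)c(S(=O)(=O)c2ccc(F)cc2F)cc2cnc(Nc3cccc4[nH]ccc34)nc21`) gives 750 nM. Compound 3 (`Cn1ccc2cc(Nc3ncc4cc(S(=O)(=O)c5ccc(F)cc5F)c(=O)n(C)c4n3)ccc21`) gives 750 nM. Both of these carry methyl on the aromatic nitrogen where compound 1 carries (methoxycarbonyl)methyl. Compound 4 (`O=c1c(S(=O)(=O)c2ccc(F)cc2F)cc2cnc(Nc3ccc4[nH]ccc4c3)nc2n1C1CC1`) keeps the rest of compound 1 and puts cyclopropyl on that nitrogen: cyclopropyl in place of (methoxycarbonyl)methyl on an aromatic nitrogen.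

Within the data shown here, no measured step isolates the group on this nitrogen. Among the measured compounds shown here, the only step available shows no change at the digits printed from compound 2 to compound 3 (within the scatter), and it concerns the indolyl group, so it bears on the change only indirectly. On these data alone, with that step flat, compound 4 is expected to move away from the number of compound 1 and toward that of compound 3 at 750 nM, though cyclopropyl itself is untested. The expected change in this assay is a lower number, estimated as an 8.3-fold lower number from compound 1 to compound 4 (0.92 log units; beyond the scatter). For compound 4 the estimate is 1200 nM, with an expected range of 300 nM to 5000 nM.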

Compound 4, half-maximal inhibitory concentration: 500 nM
Estimate against measurement, compound 4: 2.4-fold (0.38 log units) above; measured number inside the range.
By their numbers in this assay, from the lowest: compounds 4, 2 and 3 (each within the scatter of the next); then compound 1.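

In this assay, within the data shown here, the exchange of (methoxycarbonyl)methyl for cyclopropyl on the aromatic nitrogen gives a 20-fold lower number from compound 1 to compound 4 (1.30 log units; beyond the scatter), the first measured step that isolates this position. Among these compounds, the number therefore depends strongly on the group carried here, whereas the only earlier step concerned the indolyl group and was flat. The step swaps a ring-free chain with a double bond and hydrogen-bond acceptors for a three-membered carbon ring, but nothing available assigns it to any one of these differences.

The compounds shown leave open whether the step follows the methyl ester or the chain as a whole, which a carboxylic acid, a primary amide or a plain ethyl group on this nitrogen could separate. Also open, on these data alone, is whether cyclopropyl gives a similar step with 1H-indol-4-yl or 1-methyl-1H-indol-5-yl in place of the indolyl group of compound 4.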